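Replacing a Chlorophenyl Group with an Isopropoxyphenyl Group

The source may report more compounds than this note shows. Statements on the series, on what has been measured and on what is new or still open speak of the compounds shown alone.

For the measured compounds named here, compound 1 `COc1cccc(OC)c1OCCNCCOc1ccccc1OCc1cccc(Cl)c1` gives 8.12 in a functional assay on Vas deferens for antagonist activity at Alpha-1A adrenergic receptor (Rattus norvegicus) (on this read-out lower numbers stand for lower potency and higher numbers for higher potency (the scale is a negative logarithm)), the lower of the two numbers measured so far, since compound 2 `COc1cccc(OC)c1OCCNCCOc1ccccc1OCc1cccc([N+](=O)[O-])c1` gives 8.85 in this assay, a gap of a number 0.73 log units higher from compound 1 to compound 2 (beyond the scatter). Compound 3 `COc1cccc(OC)c1OCCNCCOc1ccccc1OCc1ccc(OC(C)C)cc1` differs from compound 1 in one place: 4-isopropoxyphenyl in place of 3-chlorophenyl on a saturated chain carbon bound to an oxygen on an aromatic ring. Going by the values given here, no measured step covers this change; the only step known concerns nitro in place of chloro and offers no guide to 4-isopropoxyphenyl, so no step beyond the scatter is expected. Compound 3 is therefore estimated at 8, between 7.3 and 8.7, meaning an expected step of a number 0.12 log units lower from compound 1 to compound 3 (within the scatter).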

Compound 3, negative logarithm of the antagonist equilibrium constant: 8.17
The estimate for compound 3 lay 0.17 log units below the measured number; measured number inside the range.
By their numbers in this assay, from the lowest: compounds 1 and 3 (each within the scatter of the next); then compound 2.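

In this assay, 4-isopropoxyphenyl in place of 3-chlorophenyl gives a number 0.05 log units higher from compound 1 to compound 3 (within the scatter), so at this position a group with more heavy atoms and one hydrogen-bond acceptor leaves the number within the scatter. Against 3-nitrophenyl, the same group gives a number 0.68 log units lower from compound 2 to compound 3 (beyond the scatter), leaving compound 2 as the only compound beyond the scatter of the others. No evidence bearing on the cause of these results is available. The compounds shown leave open how an aminophenyl or a carboxyphenyl group would compare at this position.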